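The source may hold more compounds than are shown below. What is called first, only, known or untested is meant among the compounds shown, and "the series" means these compounds.

Measured in a functional assay on A549 cells (Homo sapiens) for cytotoxicity, read by MTT assay, with a stated time of 72 h; a lower number here means a stronger inhibitor, a higher number a weaker inhibitor:
- compound 1 `CNC(=O)c1cc(Oc2ccc(NC(=O)c3cc(-c4ccc(Br)cc4)ncn3)cc2)ccn1`: > 100000 nM
- compound 2 `CCc1ccc(-c2cc(C(=O)Nc3ccc(Oc4ccnc(C(=O)NC)c4)c(F)c3)ncn2)cc1`: 3390 nM

Compound 1 reads > 100000 nM, which is a limit of this assay and not a number. Among the measured compounds shown here, compound 2, at 3390 nM, holds the only true number so far.

Still unmeasured is compound 3 `CNC(=O)c1cc(Oc2ccc(NC(=O)c3cc(-c4ccc(Br)cc4)ncn3)cc2F)ccn1`. Relative to compound 2, the change is bromo in place of ethyl on an aromatic carbon, that is, 4-ethylphenyl to 4-bromophenyl on an aromatic carbon, para to a large group. For the measured compounds named here, no step between measured compounds isolates this change, so any expectation for it is weakly founded. The 4-bromophenyl group also occurs in compound 1, whose reading of > 100000 nM is a limit.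

On that single reference, a moderate shift toward weaker inhibition is expected in this assay, and compound 3 may also return only a limit. The expected change is a 2.4-fold higher number from compound 2 to compound 3 (0.37 log units; beyond the scatter). For compound 3 the estimated value is 8000 nM, with an expected range of 2000 nM to 50000 nM.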

Compound 3, half-maximal inhibitory concentration: > 100000 nM
Compound 3: only a limit was reported; the forecaster's own chance of this, stated with the estimate: 25%; middle value at least 12-fold (1.09 log units) away from the limit.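

In this assay, among the compounds shown here, bromo in place of ethyl on an aromatic carbon, para to a large group, gives an at least 29-fold higher number from compound 2 to compound 3 (1.46 log units; beyond the scatter), the first readable step and a large one. For the compounds shown here, the earlier compounds held no comparison at this place, so this step is the first sign that the 4-ethylphenyl to 4-bromophenyl difference alone can separate a measurable value from a limit, with the rest of the structure unchanged. The fluoro in place of hydrogen step between the two 4-bromophenyl compounds cannot be read, and with bromo in this place, fluoro gives no visible gain in this series: the limit of > 100000 nM in this assay, at which 2 of the 3 values shown sit.

Going by these compounds alone, the 4-ethylphenyl group is seen only with the fluoro present, so what fluoro in place of hydrogen does alongside ethyl remains open. Within the data shown here, with compound 2 as the only true number, it also remains open whether the ethyl is a special case or one of several tolerated groups at this place, such as methyl, a longer chain like propyl, chloro or methoxy.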